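A few compounds are considered here, and "the series" means these few. Any claim that something is new, unique, unknown or untested is made for them only; others in the source may bear on it.

Compound 3 `O=C(O)CCC(=O)Nc1nc2ccc(NC(=O)c3c(Cl)cccc3Cl)cc2s1` belongs to a small set of amide-bearing compounds sharing one core. In a functional assay on WI-38 VA13 cells (Homo sapiens) for cytotoxicity (a lower number here means that less compound is needed, a higher number that more compound is needed for the effect), compound 3 gives only a limit, > 6.6 ug/mL, and no number. Among the others, compound 1 `CCCC(C)C(=O)Nc1ccc2nc(NC(=O)C3CCCCC3)sc2c1` gives 0.14 ug/mL, and compound 2 `Cc1cc(C(=O)Nc2ccc3nc(NC(=O)C4CCCCC4)sc3c2)n(C)n1` gives 0.12 ug/mL; the one directly comparable pair, compound 1 and compound 2, shows a 1.2-fold lower number from compound 1 to compound 2 (0.07 log units; within the scatter). So the only measured step sits at another position and changes nothing about the amide that differs here, and the fact that the limit of > 6.6 ug/mL in this assay, at which 1 of the 3 values shown sits, leaves no measured step bearing on the change to compound 4.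

Compound 4 `O=C(Nc1nc2ccc(NC(=O)c3c(Cl)cccc3Cl)cc2s1)Oc1ccccc1` differs from compound 3 by phenoxy in place of 2-carboxyethyl on a carbonyl carbon. The carboxylic acid of the 2-carboxyethyl group thus leaves and an aromatic phenoxy group enters. Compounds 1 and 2 carry no such acid and give numbers rather than a limit, which is the only available hint. Compound 4 is therefore expected to give a number, estimated at 1.5 ug/mL with a range of 0.3 ug/mL to 8 ug/mL, an expected step of an at least 4.4-fold lower number from compound 3 to compound 4 (0.64 log units; beyond the scatter).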

Compound 4, half-maximal effective concentration: 1.1 ug/mL
Compound 4: the middle estimate sits 1.4-fold (0.13 log units) above what was measured; the measured number falls inside the stated range.
By their numbers in this assay, from the lowest: compounds 2 and 1 (each within the scatter of the next); then compound 4. At a limit, above all of these: compound 3.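

In this assay, putting phenoxy in place of 2-carboxyethyl on a carbonyl carbon gives an at least 6.0-fold lower number from compound 3 to compound 4 (0.77 log units; beyond the scatter). For the compounds shown here, this is the only measured step at this amide, and it shows that a change here can move the number beyond the scatter, whereas the one earlier step, made at another position, stayed within it. From the compounds shown here alone, the true size of the step remains open-ended, since compound 3 gives a limit and no number: the limit of > 6.6 ug/mL in this assay, at which 1 of the 4 values shown sits.

The carboxylic acid leaves and the aromatic ring enters in one step, and the compounds shown do not separate these two changes. A methyl ester of the same chain, which lacks the acid but has no aromatic ring, or a benzyl group, which keeps a ring without the phenoxy oxygen, would help show which part of the change matters.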